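Shifting the methoxy on the arylpiperazine of compound 1

The compounds below may be only part of what the source reports. "The series", "measured", "known", "first", "only" and "open" are said of these compounds alone.

Compound 1 `Cc1ccc(N2CCN(Cn3nc(-c4ccc5c(c4)OCCO5)oc3=S)CC2)c(C)c1` stands at the edge of a functional assay on HeLa cells (Homo sapiens) for antiproliferative activity, read by MTT assay, with a stated time of 48 h; on this read-out higher numbers stand for weaker inhibition and lower numbers for stronger inhibition: in this assay compound 1 gives > 50000 nM, which is a limit rather than a number. Compound 2 `Fc1ccccc1N1CCN(Cn2nc(-c3ccc4c(c3)OCCO4)oc2=S)CC1` gives 37300 nM. Compound 3 `COc1ccccc1N1CCN(Cn2nc(-c3ccc4c(c3)OCCO4)oc2=S)CC1` gives > 50000 nM, again a limit. The steps of an at least 1.3-fold lower number from compound 1 to compound 2 (0.12 log units; that floor lies within the scatter) and a step that the two limits leave unreadable from compound 1 to compound 3 are the ones that bear on the present change, and both keep the compounds at or close to the limit of > 50000 nM in this assay, at which 2 of the 3 values shown sit. Compound 4 `COc1cccc(N2CCN(Cn3nc(-c4ccc5c(c4)OCCO5)oc3=S)CC2)c1` carries 3-methoxyphenyl in place of 2,4-dimethylphenyl on an amine nitrogen in a ring. No step beyond the scatter is therefore expected in this assay, and compound 4 is estimated at 50000 nM with a range from 25000 nM to 100000 nM, which amounts to an expected step of a number no higher from compound 1 to compound 4 (the limit leaves the size open).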

Compound 4, half-maximal inhibitory concentration: 18000 nM
Compound 4: middle estimate off by 2.8-fold (0.44 log units), on the high side, and the stated range ends above it.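

Among these compounds, the 3-methoxyphenyl group gives the first step beyond the scatter in this assay: with 3-methoxyphenyl in place of 2-methoxyphenyl, the result is an at least 2.7-fold lower number from compound 3 to compound 4 (0.44 log units; beyond the scatter). Against the other two groups, the change gives an at least 2.7-fold lower number from compound 1 to compound 4 (0.44 log units; beyond the scatter) and a 2.1-fold lower number from compound 2 to compound 4 (0.32 log units; beyond the scatter), which makes compound 4 the most potent of the four compounds shown.

From the compounds shown here alone, how large the two steps from compound 1 and compound 3 really are stays open, as both of those compounds stand at a limit: the limit of > 50000 nM in this assay, at which 2 of the 4 values shown sit. Whether a 3-ethoxyphenyl or a 3-aminophenyl group would hold this level also stays open.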